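Series notes: inverted ring stereocentre, compound 1 to compound 3

This account rests on a few compounds, and the source may have more. Where it says the series, first, only, none or still open, it means among the compounds named here.

Measured so far:
Compound 1 `CC(C)[C@@H](c1ccc(-c2ccc3cccc(F)c3c2)[nH]c1=O)[C@@H]1OC(=O)NC1=O` gives 85 nM in an assay on membranes from Chem-1 cells for displacement of a labelled ligand from prostaglandin E2 receptor EP3 subtype (Homo sapiens), read by scintillation counting, with a stated time of 2 h; on this read-out higher numbers stand for weaker inhibition and lower numbers for stronger inhibition.
Compound 2 `O=C1NC(=O)/C(=C/C2(c3ccc(-c4ccc5cccc(F)c5c4)[nH]c3=O)CC2)O1` gives 28 nM in this assay.

Of the two numbers, compound 1 stands highest; compound 2 shows the lower number, and the gap between the two values lies beyond the usual scatter. Among the measured compounds shown here, no step between these two is computed, so only the two values themselves are compared here.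

Compound 3 `CC(C)[C@@H](c1ccc(-c2ccc3cccc(F)c3c2)[nH]c1=O)[C@H]1OC(=O)NC1=O` is the next candidate. Against compound 1 the change is the two compounds have the same atoms and bonds and differ only in configuration as drawn: 1 of 2 stereo elements differ; a stereocentre at a saturated ring carbon is drawn S in compound 1 and R in compound 3. For the measured compounds named here, no measured pair shares this kind of change, so the size of such a step is not known from the data. The expectation for this assay is a step toward a higher number, probably beyond the scatter, though with wide uncertainty in both directions. The value expected for compound 3 is 300 nM, with a range from 60 nM to 2000 nM. The step this estimate implies is a 3.5-fold higher number from compound 1 to compound 3 (0.55 log units; beyond the scatter).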

Compound 3, inhibition constant: 27 nM
Compound 3: the middle estimate sits 11-fold (1.05 log units) above what was measured; the whole stated range lies above it.
By their numbers in this assay, from the lowest: compounds 3 and 2 (each within the scatter of the next); then compound 1.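

In this assay, the stereocentre at the saturated ring carbon is now shown to affect the read-out, which compounds 1 and 2 alone could not show, as they offered no step at this position. Inverting it from S to R gives a 3.1-fold lower number from compound 1 to compound 3 (0.50 log units; beyond the scatter), so the R form as drawn in compound 3 goes with the lower number, although the step is modest. The step can be assigned to this single stereocentre because of the following: the fact that compounds 1 and 3 differ only in the configuration as drawn.

The compounds shown leave open what inverting the second stereo element would do, since it is drawn alike in compound 1 and compound 3. On these data alone, it is also open whether the preference for R would persist if a carboxylic acid replaced the ring that carries this stereocentre.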